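Moving the Chlorine: From Compound 3 to Compound 4

The source may report more compounds than this note shows. Statements on the series, on what has been measured and on what is new or still open speak of the compounds shown alone.

In a functional assay on B16 cells (Mus musculus) for inhibition (on this read-out higher numbers stand for weaker inhibition and lower numbers for stronger inhibition), compound 1 `Cc1ccc(CNC(=O)/C=C/c2ccc(O)c(O)c2)cc1` gives 3700 nM, compound 2 `O=C(/C=C/c1ccc(O)c(O)c1)NCc1ccc(C(F)(F)F)cc1` gives 1600 nM and compound 3 `O=C(/C=C/c1ccc(O)c(O)c1)NCc1cccc(Cl)c1` gives 6000 nM. The reading for compound 3 cannot be told apart from its nearest neighbour, as the data show a 1.6-fold higher number from compound 1 to compound 3 (0.21 log units; within the scatter). Its number is clearly higher than that of compound 2 alone.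

Compound 4 `O=C(/C=C/c1ccc(O)c(O)c1)NCc1ccc(Cl)cc1` has the same atoms as compound 3, joined differently: 4-chlorophenyl in place of 3-chlorophenyl on a saturated chain carbon bound to an amide-type nitrogen. The 4-chlorophenyl enters in place of the 3-chlorophenyl, on a saturated chain carbon bound to an amide-type nitrogen.

For the measured compounds named here, no measured pair isolates this move. The closest comparison changes both the group and its place, and it stays small: a 1.6-fold higher number from compound 1 to compound 3 (0.21 log units; within the scatter). The other measured step is a 2.3-fold lower number from compound 1 to compound 2 (0.36 log units; beyond the scatter), a modest change between two groups. Compound 4 places its chlorine as compound 1 places its methyl and compound 2 its trifluoromethyl, so its number is expected to fall near the values of those two, with compound 1 at 3700 nM and compound 2 at 1600 nM. The expected change is therefore modest and toward a lower number, a 2.1-fold lower number from compound 3 to compound 4 (0.33 log units; beyond the scatter). For compound 4 the estimated value is 2800 nM, with an expected range from 1200 nM to 6500 nM.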

Compound 4, half-maximal inhibitory concentration: 1800 nM
Beside the measured number, compound 4's estimate is 1.6-fold (0.19 log units) above it; measured number inside the range.
By their numbers in this assay, from the lowest: compounds 2 and 4 (each within the scatter of the next); then compounds 1 and 3 (each within the scatter of the next).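

Moving the chlorine is the first change here that alters place alone, with the atoms unchanged: in this assay there is a 3.3-fold lower number from compound 3 to compound 4 (0.52 log units; beyond the scatter) and this puts the effect of where the chlorine sits beyond the scatter, which the earlier steps, each changing the group itself, could not do. With the place held fixed, the groups separate unevenly: a 1.1-fold higher number from compound 2 to compound 4 (0.05 log units; within the scatter) leaves chloro and trifluoromethyl indistinguishable, whereas a 2.1-fold lower number from compound 1 to compound 4 (0.31 log units; beyond the scatter) sets chloro apart from methyl, though only modestly. Nothing available bears on why the place of the chlorine should matter in this way.

On these data alone, only chloro has been seen at both places, so it remains open whether methyl or trifluoromethyl would show a similar shift on moving from the 4-substituted to the 3-substituted phenyl. Also open, as far as these compounds go, is how a bromo, a methoxy or an amine in place of the chlorine would read in this assay and whether a longer chain between the amide-type nitrogen and the aromatic ring would preserve the difference seen between the two chlorophenyl groups.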